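A Benzyl Ether Replaces the Aryl Ether in Compound 4

A few compounds are considered here, and "the series" means these few. Any claim that something is new, unique, unknown or untested is made for them only; others in the source may bear on it.

Three ureas built on a shared core have been measured in a functional assay on CRL2813 cells (Homo sapiens) for cytotoxicity, read by sulforhodamine B assay, with a stated time of 5 days; on this read-out lower numbers stand for stronger inhibition and higher numbers for weaker inhibition. Compound 1 `O=C(Nc1cccc(Cl)c1)N[C@H]1CC[C@H](Oc2ccc(F)cc2)CC1` gives 5900 nM in this assay. Compound 3 `O=C(Nc1ccc(I)cc1)N[C@H]1CC[C@H](Oc2ccc(F)cc2)CC1` gives 10200 nM. The change a 1.7-fold higher number from compound 1 to compound 3 (0.24 log units; within the scatter), with 4-iodophenyl in place of 3-chlorophenyl on an amide-type nitrogen, stays within the scatter. Compound 2 `O=C(Nc1cccc(C(F)(F)F)c1)N[C@H]1CC[C@H](Oc2ccc(Cl)cc2)CC1` gives 2000 nM, the lowest of the three numbers, and its gaps to compound 1 and to compound 3 both exceed the scatter. Compound 4 `O=C(Nc1cccc(C(F)(F)F)c1)N[C@H]1CC[C@H](OCc2ccc(F)cc2)CC1` differs from compound 2 on an oxygen on a saturated carbon: 4-fluorobenzyl in place of 4-chlorophenyl on an oxygen on a saturated carbon. Going by the values given here, no measured step touches this part of the molecule; the one recorded step concerns the nitrogen-bound aryl group only and was small. With nothing to anchor the direction, a modest change at most is expected, and compound 4 is estimated at 3500 nM with a range from 1200 nM to 10000 nM. The step of a 1.8-fold higher number from compound 2 to compound 4 (0.24 log units; within the scatter) so expected is small.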

Compound 4, half-maximal inhibitory concentration: 2650 nM
Beside the measured number, compound 4's estimate is 1.3-fold (0.12 log units) above it, and the stated range covers the measured number.
By their numbers in this assay, from the lowest: compounds 2 and 4 (each within the scatter of the next); then compounds 1 and 3 (each within the scatter of the next).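

In this assay, going by these compounds alone, the swap of 4-chlorophenyl for 4-fluorobenzyl on an oxygen on a saturated carbon gives a 1.3-fold higher number from compound 2 to compound 4 (0.12 log units; within the scatter) and so provides the first reading at this position, where the two groups cannot be told apart. The step exchanges chlorine for fluorine and adds one carbon to the group at the same time, so it cannot show what each of these contributes alone. No measured evidence offers an explanation for the result.

A 4-chlorobenzyl group on the same oxygen would separate the halogen from the added carbon, but the compounds shown do not include it. They also leave open how a longer chain such as 2-phenylethyl, or a group carrying an amine or a carboxylic acid, would read at this position.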